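The compounds below may be only part of what the source reports. "The series", "measured", "known", "first", "only" and "open" are said of these compounds alone.

In a functional assay on CHO cells for agonist activity at Alpha-1A adrenergic receptor (Homo sapiens), read by FLIPR and calcium flux (a higher number here means a larger maximal response, a lower number a smaller maximal response), compound 2, with the structure `COCc1ccccc1C1Cc2nccn2C1`, gives 77%, the higher of the two single numbers in hand. Compound 3, built as `Clc1cccc(C2CCc3nc[nH]c3C2)c1`, gives 71%, a number within the scatter of compound 2, so the two cannot be ranked. Compound 1, with the structure `COCc1ccccc1C1CCc2nc[nH]c2C1`, has been run repeatedly and gives 87%; 83% (2 entries); the spread of these entries, shown in the several entries of compound 1 in this assay, 87%; 83% (2 entries), gives a feel for how far repeated runs of this assay can drift.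

Compound 4, whose structure is `COc1ccccc1C1Cc2nccn2C1`, has not yet been run in this assay. It differs from compound 2 in one place: methoxy in place of methoxymethyl on an aromatic carbon. Going by the values given here, no pair of measured compounds shows this same change, so there is no measured step to lean on. Given that compound 2 gives 77% and compound 3 gives 71%, the expectation is a step of a number 5 percentage points lower from compound 2 to compound 4 (within the scatter), not beyond the scatter. Compound 4 is therefore estimated to give 72% in this assay, most likely between 55% and 90%.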

Compound 4, largest response reached (Emax), in percent of the reference or control that the assay uses: 82%
Beside the measured number, compound 4's estimate is 10 percentage points below it, within the range that was stated.
By their numbers in this assay, from the lowest: compounds 3, 2 and 4 (each within the scatter of the next, the first and the last beyond it).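

Methoxy in place of methoxymethyl on an aromatic carbon, ortho to a group of 8 heavy atoms, gives the first measured step at this position: in this assay it amounts to a number 5 percentage points higher from compound 2 to compound 4 (within the scatter). At this place, then, the two groups cannot be told apart in the response, and both compound 2 and compound 4 can be read only as giving a similar maximal response. Repeat runs of a single compound show a spread of comparable size, so the step is not read as a real difference: the several entries of compound 1 in this assay, 87%; 83% (2 entries)

As far as these compounds go, whether a group of another kind at this place, such as an amine, a carboxylic acid or a longer chain, would move the response beyond the scatter remains open. From the compounds shown here alone, it is also open whether the same change would give a similar step on the core of compound 1.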